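The compounds below may be only part of what the source reports. "The series", "measured", "known", "first", "only" and "open" are said of these compounds alone.

Working notes on the series, read in a functional assay, read by fluorescence and spectrophotometry, with a stated time of 1 h; on this read-out lower numbers stand for an effect already at smaller amounts and higher numbers for an effect only at larger amounts of compound. Compound 1 (`CCCCCCS(=O)(=O)/C=C/c1ccc(O)c(O)c1`) gives 7300 nM, compound 2 (`O=S(=O)(/C=C/c1ccc(O)c(O)c1)CCCCCCCCO`) gives 6700 nM, and compound 3 (`O=S(=O)(/C=C/c1ccc(O)c(O)c1)CCCCCCCCCO`) gives 7500 nM. Compound 3 therefore stands level with the other two, as all three values lie within the scatter of one another.

The next compound is compound 4 (`O=S(=O)(/C=C/c1ccc(O)c(O)c1)CCCc1ccccc1`), with the change phenyl in place of 6-hydroxyhexyl on a saturated chain carbon, three bonds along the chain from a sulfonyl sulfur.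

Going by the values given here, three measured steps bear on this: a 1.1-fold lower number from compound 1 to compound 2 (0.04 log units; within the scatter), a 1.0-fold higher number from compound 1 to compound 3 (0.01 log units; within the scatter) and a 1.1-fold higher number from compound 2 to compound 3 (0.05 log units; within the scatter). All three stay within the scatter, but each alters only the saturated chain and none brings in a ring, so they are indirect precedent for phenyl. No step beyond the scatter is expected in this assay, in either direction, though the range stays wide. The expected change is a 1.3-fold lower number from compound 3 to compound 4 (0.10 log units; within the scatter). Compound 4 is estimated at 6000 nM, with an expected range of 2500 nM to 14000 nM.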

Compound 4, half-maximal effective concentration: 11500 nM
Estimate against measurement, compound 4: 1.9-fold (0.28 log units) below; measured number inside the range.
By their numbers in this assay, from the lowest: compounds 2, 1, 3 and 4 (each within the scatter of the next).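

Phenyl on a saturated chain carbon, three bonds along the chain from a sulfonyl sulfur, gives a 1.5-fold higher number from compound 3 to compound 4 (0.19 log units; within the scatter) and a 1.7-fold higher number from compound 2 to compound 4 (0.23 log units; within the scatter) and a 1.6-fold higher number from compound 1 to compound 4 (0.20 log units; within the scatter) in this assay with every step inside the scatter. The earlier steps shown here altered only the saturated chain, whereas these show that a six-membered aromatic ring of carbon only, with no hydrogen-bond donor or acceptor, also stays level with all three chain compounds at this place. Nothing at hand bears on why the read-out holds across this change.

From the compounds shown here alone, whether an amine or a carboxylic acid at the end of the chain would carry the number beyond the scatter remains open. Also open, going by these compounds, is whether a hydroxy group on the phenyl ring, or phenyl at the end of a longer chain, would do so.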